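From Methyl to Bromo on a Shared Core

The source may report more compounds than this note shows. Statements on the series, on what has been measured and on what is new or still open speak of the compounds shown alone.

Measured in a physicochemical assay for lipophilicity, at pH 7.4; a lower number here means a more polar compound, a higher number a more lipophilic compound:
- compound 1 `Cc1[nH]c2ccc(Cl)cc2c(=O)c1Br`: 2.02
- compound 2 `COc1cc2[nH]c(C)c(C)c(=O)c2cc1Cl`: 1.86

Only these two compounds have been measured, and compound 2 at 1.86 lies within the scatter of compound 1 at 2.02. The next compound, compound 3 `COc1cc2[nH]c(C)c(Br)c(=O)c2cc1Cl`, departs from compound 2 in one place, with bromo in place of methyl on an aromatic carbon. Among the measured compounds shown here, no measured pair shows this exchange on its own. For the measured compounds named here, the only guide is compound 1, which also carries bromo and gives 2.02, though it differs from compound 3 elsewhere. A small upward move in this assay is therefore expected, not clearly beyond the scatter. The estimated change is a number 0.19 log units higher from compound 2 to compound 3 (within the scatter). For compound 3 the expected value is 2.05, with an estimated range of 1.7 to 2.4.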

Compound 3, distribution coefficient: 0
Compound 3: the middle estimate sits 2.05 log units above what was measured, outside the stated range (below it).
By their numbers in this assay, from the lowest: compound 3; then compounds 2 and 1 (each within the scatter of the next).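

In this assay, bromo in place of methyl on an aromatic carbon gives a number 1.86 log units lower from compound 2 to compound 3 (beyond the scatter), so this single exchange at this position can carry a large step. Methoxy in place of hydrogen on an aromatic carbon, with bromo present on both sides of the pair, gives a number 2.02 log units lower from compound 1 to compound 3 (beyond the scatter), which shows that carrying bromo does not on its own settle the number in this series. Nothing available explains either step.

Going by these compounds, each exchange is seen only once, so it remains open whether the large step belongs to bromo at this position alone or appears only when bromo and methoxy occur together. The compounds shown also leave open how an amine or a longer chain on this aromatic carbon would read in this assay.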